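The source may report more compounds than this note shows. Statements on the series, on what has been measured and on what is new or still open speak of the compounds shown alone.

The measured compounds:

- compound 1 `Oc1ccc(/C=C2\CCN=C2c2cccnc2)c(O)c1`: in an assay for displacement of a labelled ligand from Nicotinic acetylcholine receptor alpha8 subunit (Periplaneta americana), read by scintillation counting, with a stated time of 2 h, at 24 degrees C (on this read-out higher numbers stand for weaker inhibition and lower numbers for stronger inhibition), compound 1 gives 120 nM
- compound 3 `COc1ccc(/C=C2\CCN=C2c2cccnc2)c(O)c1`: in this assay compound 3 gives 3890 nM
- compound 2 `Oc1cccc(/C=C2\CCN=C2c2cccnc2)c1`: for compound 2 this assay reports only a limit, > 10000 nM

Compound 1 and compound 3 differ in one place, (methyl in place of hydrogen on an oxygen on an aromatic ring), and this change produced a 32-fold higher number from compound 1 to compound 3 (1.51 log units; beyond the scatter). The data give no cause for this step beyond the measurement itself.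

Compound 2 carries the same core shared by the set, but the difference between the two cores of compound 1 and compound 2 is not broken down here. What the two values show is that compound 1 gives a number, while compound 2 sits at the limit of this assay, (the limit of > 10000 nM in this assay, at which 1 of the 3 values shown sits).

Compound 4 `COc1cccc(/C=C2\CCN=C2c2cccnc2)c1` has not yet been measured. Going by the values given here, it differs from compound 2 by methyl in place of hydrogen on an oxygen on an aromatic ring, which is the same change as the one from compound 1 to compound 3; the surroundings of the place are the same in both pairs.

The expected step is a step that the limit leaves unreadable from compound 2 to compound 4, estimated on the basis that the same change gave a 32-fold higher number from compound 1 to compound 3 (1.51 log units; beyond the scatter) and that compound 2 already stands at the limit (the limit of > 10000 nM in this assay, at which 1 of the 3 values shown sits). Compound 4 is therefore expected to fall around 40000 nM, between 8000 nM and 300000 nM, and most probably to be reported only as a limit again.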

Compound 4, half-maximal inhibitory concentration: > 10000 nM
Compound 4 was reported as a limit; the forecaster's own chance of this, stated with the estimate: 90%; the middle value lies beyond the limit too.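

Going by these compounds alone, compound 2 and compound 4 are both reported only as limits in this assay, so no step between them can be read, and the hydroxy to methoxy change cannot be sized for this pair: the limit of > 10000 nM in this assay, at which 2 of the 4 values shown sit. The compounds shown leave open where compound 2 and compound 4 truly lie past that limit, and whether the change seen as a 32-fold higher number from compound 1 to compound 3 (1.51 log units; beyond the scatter) has a counterpart in this pair.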